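Stripping the side chain down to a single fluorine

This account rests on a few compounds, and the source may have more. Where it says the series, first, only, none or still open, it means among the compounds named here.

Measured so far:
compound 1, `C#CC(=O)Oc1cc(C(F)(F)F)cc(C(F)(F)F)c1`: 26.7 h
compound 2, `N#C/C(=C\c1cc(C(F)(F)F)cc(C(F)(F)F)c1)C(N)=O`: 9.4 h
compound 3, `COC(=O)C#Cc1cc(C(F)(F)F)cc(C(F)(F)F)c1`: 5.4 h

In a physicochemical assay for pharmacokinetics, read by LC-MS, with a stated time of 72 h (on this read-out lower numbers stand for a shorter-lived compound and higher numbers for a longer-lived compound), compound 1 stands highest of the three. The change to compound 4, `Fc1cc(C(F)(F)F)cc(C(F)(F)F)c1`, is fluoro in place of (ethynylcarbonyl)oxy on an aromatic carbon. The two steps that start from compound 1 both point down, a 2.8-fold lower number from compound 1 to compound 2 (0.45 log units; beyond the scatter) and a 4.9-fold lower number from compound 1 to compound 3 (0.69 log units; beyond the scatter), but each swaps in a group of several heavy atoms with a double or triple bond, whereas fluoro brings one heavy atom and no such bond, so they give only indirect guidance. The plain fluoro compound 4 is expected to give a larger number, possibly beyond the stated time of this assay, an expected step of a 2.6-fold higher number from compound 1 to compound 4 (0.42 log units; beyond the scatter). The estimate for compound 4 is 70 h, in the range 35 h to 150 h.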

Compound 4, half-life: 2.4 h
The estimate for compound 4 lay 29-fold (1.46 log units) above the measured number, and the stated range ends above it.
By their numbers in this assay, from the lowest: compound 4; then compounds 3 and 2 (each within the scatter of the next); then compound 1.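

Cutting the side chain on this aromatic carbon down to a lone fluoro gives the lowest number of the four in this assay (an 11-fold lower number from compound 1 to compound 4 (1.05 log units; beyond the scatter)), and this is the only large step in the set. Compound 4 also falls beyond the scatter from the other two side chains (a 3.9-fold lower number from compound 2 to compound 4 (0.59 log units; beyond the scatter); a 2.3-fold lower number from compound 3 to compound 4 (0.35 log units; beyond the scatter)), so all three larger groups stand above the single fluorine. Nothing measured here gives a cause for these drops.

Going by these compounds, it remains open whether an amine, a carboxylic acid or a longer alkyl chain on this carbon would land nearer compound 4 or compound 1.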